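The source may report more compounds than this note shows. Statements on the series, on what has been measured and on what is new or still open speak of the compounds shown alone.

Working notes on the series. The three measured compounds share one core and differ only in the group carried on an aromatic nitrogen of a five-membered aromatic ring with 3 nitrogen. In a functional assay on MCF7 cells (Homo sapiens) for inhibition, read by MTT assay, with a stated time of 24 h (on this read-out lower numbers stand for stronger inhibition and higher numbers for weaker inhibition), compound 1 `CCOC(=O)C1=Cc2ccccc2OC1(OCc1cn(CC(=O)Nc2ccc(C)cc2)nn1)C(F)(F)F` gives only a limit, > 150000 nM; this is the limit recorded as the limit of > 150000 nM in this assay, at which 1 of the 3 values shown sits. Compound 2 `CCOC(=O)C1=Cc2ccccc2OC1(OCc1cn(CC(=O)Nc2ccccc2F)nn1)C(F)(F)F` gives 42100 nM in this assay. Compound 3 `CCOC(=O)C1=Cc2ccccc2OC1(OCc1cn(-c2ccc(F)c([N+](=O)[O-])c2)nn1)C(F)(F)F` gives 16200 nM in this assay, the lowest of the two numbers, with compound 2 nearest. The step of a 2.6-fold lower number from compound 2 to compound 3 (0.41 log units; beyond the scatter) and the step of an at least 9.2-fold lower number from compound 1 to compound 3 (0.96 log units; beyond the scatter) both run from a carbamoylmethyl chain to an aryl group on that ring nitrogen, and in each the aryl group carries the lower number.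

Compound 4 `CCOC(=O)C1=Cc2ccccc2OC1(OCc1cn(CC(=O)Nc2ccc(OC)cc2)nn1)C(F)(F)F` is not yet measured; it differs from compound 3 as ((4-methoxyphenyl)carbamoyl)methyl in place of 4-fluoro-3-nitrophenyl on an aromatic nitrogen. This reverses the kind of change seen in the two measured steps, so the number for compound 4 is expected to move back toward those of compound 1 and compound 2, whose chains are of the same kind as the entering group. The step is therefore expected to be an increase, a 3.7-fold higher number from compound 3 to compound 4 (0.57 log units; beyond the scatter). Compound 4 is estimated at 60000 nM, between 20000 nM and 200000 nM, with a fair chance that only a limit is returned.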

Compound 4, half-maximal inhibitory concentration: 28100 nM
Beside the measured number, compound 4's estimate is 2.1-fold (0.33 log units) above it, within the range that was stated.
By their numbers in this assay, from the lowest: compounds 3, 4 and 2 (each within the scatter of the next, the first and the last beyond it). At a limit, above all of these: compound 1.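

Replacing 4-fluoro-3-nitrophenyl with ((4-methoxyphenyl)carbamoyl)methyl on the aromatic nitrogen gives a 1.7-fold higher number from compound 3 to compound 4 (0.24 log units; within the scatter) in this assay, so a carbamoylmethyl chain at this position can read level with an aryl group; the aryl group carries the lower number beyond the scatter against compound 1 and compound 2, and compound 4 goes against that pattern. Within the chain, 4-methoxyphenyl in place of 2-fluorophenyl on the amide-type nitrogen gives a 1.5-fold lower number from compound 2 to compound 4 (0.18 log units; within the scatter), which leaves those two chains unresolved in this assay, whereas methoxy in place of methyl on an aromatic carbon gives an at least 5.3-fold lower number from compound 1 to compound 4 (0.72 log units; beyond the scatter), showing that a single substituent on the aryl end of the chain can shift the read-out beyond the scatter. Compound 1 stands only as a limit and not as a number, so that last step is a bound and its true size stays unknown: the limit of > 150000 nM in this assay, at which 1 of the 4 values shown sits.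

The compounds shown leave open how the number moves when the aryl end of the chain carries an amine or a carboxylic acid. They also leave open what a longer chain between the amide carbonyl and the aromatic nitrogen would give.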